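A few compounds are considered here, and "the series" means these few. Any claim that something is new, unique, unknown or untested is made for them only; others in the source may bear on it.

Compound 1 `Cc1nc(S(C)(=O)=O)ccc1Oc1ncnc(OC2CCN(C(=O)O[C@@H](C)CF)CC2)c1F` gives 186 nM in a functional assay on isolated protein for inhibition of Glucose-dependent insulinotropic receptor (Homo sapiens), read by HTRF and cAMP accumulation; a lower number here means that less compound is needed, a higher number that more compound is needed for the effect. Compound 2 `Cc1nc(S(C)(=O)=O)ccc1Oc1ncnc(OC2CCN(C(=O)OC3(C(F)(F)F)CCC3)CC2)c1F` gives 14.3 nM. Compound 3 `Cc1nc(S(C)(=O)=O)ccc1Oc1ncnc(OC2CCN(C(=O)SC(C)(C)C)CC2)c1F` gives 4.83 nM.

Compound 3 has the lowest number of the three, the steps to it being a 3.0-fold lower number from compound 2 to compound 3 (0.47 log units; beyond the scatter) and a 39-fold lower number from compound 1 to compound 3 (1.59 log units; beyond the scatter). Compound 4 `Cc1nc(S(C)(=O)=O)ccc1Oc1ncnc(OC2CCN(C(=O)SC3CCC3)CC2)c1F` differs from compound 3 by cyclobutyl in place of tert-butyl on a sulfur. Among the compounds with values here, no measured step alters only the group on the sulfur, so none bears directly on this change. The steps of a 13-fold lower number from compound 1 to compound 2 (1.11 log units; beyond the scatter) and a 3.0-fold lower number from compound 2 to compound 3 (0.47 log units; beyond the scatter) both changed the whole group on the carbonyl carbon, and the ring-bearing member was the weaker one in the second of them. A step of at most modest size, in no firm direction, is therefore expected: a 1.4-fold higher number from compound 3 to compound 4 (0.16 log units; within the scatter). Compound 4 is estimated at 7 nM, between 2.5 nM and 20 nM.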

Compound 4, half-maximal effective concentration: 8.51 nM
For compound 4 the middle estimate is 1.2-fold (0.08 log units) below the measured one; the measured number falls inside the stated range.
By their numbers in this assay, from the lowest: compounds 3, 4 and 2 (each within the scatter of the next, the first and the last beyond it); then compound 1.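

In this assay, within the data shown here, this is the first step that alters only the group on the sulfur: a 1.8-fold higher number from compound 3 to compound 4 (0.25 log units; within the scatter) shows that cyclobutyl and tert-butyl are not separated here. Against the other groups on the carbonyl carbon, a 1.7-fold lower number from compound 2 to compound 4 (0.23 log units; within the scatter) and a 22-fold lower number from compound 1 to compound 4 (1.34 log units; beyond the scatter) show that the sulfur group with a ring keeps the large gap to compound 1 while standing within the scatter of compound 2. No evidence on the origin of these numbers is available. From the compounds shown here alone, whether cyclopentyl, isopropyl or an amine on the carbonyl carbon would give similar numbers remains open.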